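A few compounds are considered here, and "the series" means these few. Any claim that something is new, unique, unknown or untested is made for them only; others in the source may bear on it.

Measured in a functional assay on KB cells (Homo sapiens) for antiproliferative activity, read by colorimetric assay and MTT assay; a higher number here means a weaker inhibitor, a lower number a stronger inhibitor:
- compound 1 `COc1ccc(S(=O)(=O)Nc2cccc3cc[nH]c23)cc1`: 0.67 ug/mL
- compound 2 `O=S(=O)(Nc1cccc2cc[nH]c12)c1ccc(Cl)cc1`: 6 ug/mL

Compound 2 stands highest of the two, at 6 ug/mL, and is the weaker inhibitor. Compound 3 `O=S(=O)(Nc1cc(Cl)cc2cc[nH]c12)c1ccc(Cl)cc1` has chloro in place of hydrogen on an aromatic carbon. Within the data shown here, only one measured step bears on this, a 9.0-fold higher number from compound 1 to compound 2 (0.95 log units; beyond the scatter), and it replaced methoxy rather than hydrogen, so it is a loose guide. Among the measured compounds shown here, no measured step adds chloro in place of hydrogen, so the direction stays open, and only a small change in this assay is expected, probably none beyond the scatter. The expected change is a 1.5-fold lower number from compound 2 to compound 3 (0.18 log units; within the scatter). For compound 3 the estimated value is 4 ug/mL, with an expected range from 1 ug/mL to 15 ug/mL.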

Compound 3, half-maximal inhibitory concentration: 9.1 ug/mL
Estimate against measurement, compound 3: 2.3-fold (0.36 log units) below; measured number inside the range.
By their numbers in this assay, from the lowest: compound 1; then compounds 2 and 3 (each within the scatter of the next).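

Chloro in place of hydrogen on this aromatic carbon, meta to a large group and para to a fused ring, gives a 1.5-fold higher number from compound 2 to compound 3 (0.18 log units; within the scatter) in this assay. Among these compounds, the earlier step, a 9.0-fold higher number from compound 1 to compound 2 (0.95 log units; beyond the scatter), changed a different place, so only this step shows that the fused system can carry an added chlorine here without a change beyond the scatter.

As far as these compounds go, whether an amine or a carboxylic acid on the same carbon would also stay within the scatter remains open. So does whether chloro here would do the same alongside the methoxy of compound 1. No measured evidence bears on this result.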